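Piperazine ureas and amides on a dichlorophenoxy pyrimidine core

A few compounds are considered here, and "the series" means these few. Any claim that something is new, unique, unknown or untested is made for them only; others in the source may bear on it.

Measured so far:
compound 1, `O=C([C@H]1Cc2ccccc2N1)N1CCN(c2nccc(Oc3cc(Cl)cc(Cl)c3)n2)CC1`, in a functional assay on MDA-MB-231 cells (Homo sapiens) for antiproliferative activity, read by MTT assay, with a stated time of 24 h (on this read-out higher numbers stand for weaker inhibition and lower numbers for stronger inhibition), gives > 50000 nM
compound 2, `CC(C)(C)c1ccc(S(=O)(=O)N2CCN(c3nccc(Oc4cc(Cl)cc(Cl)c4)n3)CC2)cc1`, in this assay gives > 50000 nM

Compound 1 stands at the limit of this assay, not at a measured number. The same holds for compound 2, so neither value gives a foothold for comparison; what is shown is the limit of > 50000 nM in this assay, at which 2 of the 2 values shown sit.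

Compound 3, `O=C(Nc1ccc2ccccc2c1)N1CCN(c2nccc(Oc3cc(Cl)cc(Cl)c3)n2)CC1`, is not yet measured. It differs from compound 1 in (naphthalen-2-yl)amino in place of 2,3-dihydro-1H-indol-2-yl on a carbonyl carbon. Within the data shown here, no step between measured compounds exists here, so nothing shows how this assay responds to a change at the carbonyl carbon, and there is no basis for expecting a shift in either direction beyond the scatter. Compound 3 is therefore expected to remain at or near the limit, with a number no higher from compound 1 to compound 3 (the limit leaves the size open) expected to be no step beyond the scatter. The estimate for compound 3 is 50000 nM, within 20000 nM to 100000 nM.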

Compound 3, half-maximal inhibitory concentration: 46800 nM
The estimate for compound 3 lay 1.1-fold (0.03 log units) above the measured number, and the stated range covers the measured number.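

In this assay, among these compounds, compound 3 gives the first value that is a number and not a limit, so the place on the carbonyl carbon now has one readable point. Putting (naphthalen-2-yl)amino in place of 2,3-dihydro-1H-indol-2-yl there gives an at least 1.0-fold lower number from compound 1 to compound 3 (0.02 log units; that floor lies within the scatter), so the change is not shown to move the read-out beyond the scatter. The true size of this step cannot be read because compound 1 stands at a limit, as does compound 2: the limit of > 50000 nM in this assay, at which 2 of the 3 values shown sit.

The compounds shown leave open whether another group on this carbonyl carbon, such as a simple phenylamino group or a longer chain ending in an amine, gives a clearly lower number. Also open, as far as these compounds go, is whether changing the dichlorophenoxy group on the shared core shifts the read-out at all.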